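The source may hold more compounds than are shown below. What is called first, only, known or untested is meant among the compounds shown, and "the series" means these compounds.

Working notes on the series. Two compounds with the shared core have numbers in an assay on isolated protein for binding affinity to 5-hydroxytryptamine receptor 6 (Homo sapiens); a higher number here means a weaker inhibitor, a lower number a stronger inhibitor. Compound 1 `Cc1ccc(-c2n[nH]cc2N2CCCNCC2)cc1` gives 1320 nM in this assay. Compound 2 `Fc1cccc(-c2n[nH]cc2N2CCCNCC2)c1` gives 841 nM in this assay, and compound 1 is not separated from compound 2 beyond the scatter. Compound 3 `Fc1ccc(-c2n[nH]cc2N2CCCNCC2)cc1` is not yet measured. It differs from compound 1 in one place: fluoro in place of methyl on an aromatic carbon. For the measured compounds named here, no pair of measured compounds covers this exchange. The expected step in this assay is a 1.3-fold lower number from compound 1 to compound 3 (0.12 log units; within the scatter), small and of uncertain direction. For compound 3 the estimate in this assay is 1000 nM, with a range from 400 nM to 2500 nM.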

Compound 3, inhibition constant: 2290 nM
Estimate against measurement, compound 3: 2.3-fold (0.36 log units) below; measured number inside the range.
By their numbers in this assay, from the lowest: compounds 2, 1 and 3 (each within the scatter of the next, the first and the last beyond it).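

In this assay, for the compounds shown here, fluoro in place of methyl on an aromatic carbon, para to a large group, gives a 1.7-fold higher number from compound 1 to compound 3 (0.24 log units; within the scatter) as the first direct reading of this exchange. At this position, the two groups are therefore not separated beyond the scatter. This single pair does not show whether other groups at the same place would be separated from methyl or fluoro. Still open, going by these compounds, is whether an amine, a carboxylic acid or a longer chain here would move the number beyond the scatter. No measurement shown explains the result.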